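A few compounds are considered here, and "the series" means these few. Any claim that something is new, unique, unknown or untested is made for them only; others in the source may bear on it.

In a functional assay on SiHa cells (Homo sapiens) for inhibition, read by CCK-8 assay, with a stated time of 72 h, tested at 10 uM (on this read-out higher numbers stand for more inhibition of growth at the one concentration tested and lower numbers for less inhibition of growth), compound 1 (`CN(C)C(=O)c1cc2cnc(Nc3ccc(NC(=O)C4(C(=O)Nc5ccc(Br)cc5)CC4)cc3)nc2n1C1CCCC1`) gives 98.8% and compound 2 (`CN(C)C(=O)c1cc2cnc(Nc3ccc(NC(=O)C4(C(=O)Nc5cccc(Br)c5)CC4)cc3)nc2n1C1CCCC1`) gives 92.5%, so compound 2 stands within the scatter of compound 1. Compound 3 (`CN(C)C(=O)c1cc2cnc(Nc3ccc(NC(=O)C4(C(=O)Nc5ccc(O)cc5)CC4)cc3)nc2n1C1CCCC1`) carries 4-hydroxyphenyl in place of 3-bromophenyl on an amide-type nitrogen. Among the compounds with values here, the only measured step, a number 6.3 percentage points lower from compound 1 to compound 2 (within the scatter), relocates the bromine rather than replacing it, so it offers only weak guidance here. With compound 2 at 92.5%, little room remains upward, so a moderate drop is expected. The expected step is a number 17.5 percentage points lower from compound 2 to compound 3 (beyond the scatter). For compound 3 the estimated value is 75%, with an expected range of 45% to 97%.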

Compound 3, percent growth inhibition at one concentration: 94.3%
The estimate for compound 3 lay 19.3 percentage points below the measured number; measured number inside the range.
By their numbers in this assay, from the lowest: compounds 2, 3 and 1 (each within the scatter of the next).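

Although 4-hydroxyphenyl brings a hydrogen-bond donor and acceptor that 3-bromophenyl lacks, this assay shows a number 1.8 percentage points higher from compound 2 to compound 3 (within the scatter) and a number 4.5 percentage points lower from compound 1 to compound 3 (within the scatter). Bromine is therefore not needed on this phenyl for growth inhibition to stay high at the one concentration tested, and hydroxy in place of bromo on an aromatic carbon stays within the scatter. Nothing available explains this tolerance.

With all three compounds close to the top of the read-out, the limits of this position remain unresolved. As far as these compounds go, whether an aminophenyl or a carboxyphenyl on this nitrogen would hold the number stays open.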